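This account rests on a few compounds, and the source may have more. Where it says the series, first, only, none or still open, it means among the compounds named here.

Of the compounds shown here, three of one shared core have been measured so far. In an in vitro functional assay on cells for antagonist activity at metabotropic glutamate receptor 1 (Rattus norvegicus), read by inositol phosphate accumulation (a lower number here means a stronger inhibitor, a higher number a weaker inhibitor), compound 1 `CCCCNc1nc2c(cc1C#N)C(=O)CC(C)(C)C2` gives 1700 nM. Among the three numbers this is the second highest. The nearest neighbour is compound 3 `N#Cc1cc2c(nc1NC1CCCCCC1)CCCC2=O`, which in this assay gives 7400 nM, a higher number, and the gap between the two lies beyond the usual scatter of repeated measurements. Furthest away is compound 2 `CC1(C)CC(=O)c2cc(C#N)c(N3CCN(c4ccc(F)cc4)CC3)nc2C1`, which in this assay gives 160 nM, a lower number, and that gap too lies well beyond the scatter. Compounds 2 and 3 differ from compound 1 in more than one place, so no single structural step can be read off from them.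

The next compound, compound 4 `CCCNc1nc2c(cc1C#N)C(=O)CC(C)(C)C2`, differs from compound 1 in exactly one place: hydrogen in place of methyl on a saturated chain carbon, three bonds along the chain from a nitrogen on an aromatic ring. Within the data shown here, no pair of the measured compounds differs by such a change, so there is nothing in the data that shows how a shorter chain at this position affects the read-out. For this reason the step of a 1.5-fold higher number from compound 1 to compound 4 (0.17 log units; within the scatter) is expected to be small, within the scatter or only a little beyond it, most likely towards a slightly higher number. Compound 4 is therefore estimated to give 2500 nM, within a range from 900 nM to 7000 nM.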

Compound 4, half-maximal inhibitory concentration: 2300 nM
For compound 4 the middle estimate is 1.1-fold (0.04 log units) above the measured one, within the range that was stated.
By their numbers in this assay, from the lowest: compound 2; then compounds 1 and 4 (each within the scatter of the next); then compound 3.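

In this assay, trimming the chain on the nitrogen from butyl to propyl gives a 1.4-fold higher number from compound 1 to compound 4 (0.13 log units; within the scatter), so this single change of one carbon at the chain end leaves the read-out indistinguishable from that of compound 1. Among these compounds, this is the first comparison in the set that isolates one structural change, and it shows that at this position, on a saturated chain carbon three bonds along the chain from a nitrogen on an aromatic ring, a methyl can give way to a hydrogen without a measurable shift in this assay. No measurement offered here bears on why the two compounds read alike, so the result stands as an observation without an explanation.

On these data alone, what the chain can bear beyond this one step stays open: a still shorter ethyl or methyl group, a longer pentyl chain, or a hydroxyl group at the chain end could each read differently, and one step within the scatter does not predict any of them. Compound 2 and compound 3 each differ from compound 1 in more than one place, so neither can show how much the group on this nitrogen matters by itself.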